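Swapping Piperidinyl for Ethoxyphenylamino: Expecting Compound 3

The compounds below may be only part of what the source reports. "The series", "measured", "known", "first", "only" and "open" are said of these compounds alone.

Compound 1 `FC(F)(F)c1ccc(CSc2nc(N3CCCCC3)c3ccccc3n2)cc1`: > 50000 nM
Compound 2 `FC(F)(F)c1ccc(CSc2nc(Nc3cccc(Cl)c3)c3ccccc3n2)cc1`: 25100 nM

Both numbers come from a functional assay on MCF7 cells (Homo sapiens) for cytotoxicity, read by MTT assay, with a stated time of 72 h; on this read-out lower numbers stand for stronger inhibition and higher numbers for weaker inhibition. For compound 1 the recorded value is > 50000 nM, which is a limit of this assay and not a measured number (the limit of > 50000 nM in this assay, at which 1 of the 2 values shown sits). Compound 2 gives 25100 nM in this assay. Among the compounds with values here, the one measured step, an at least 1.9-fold lower number from compound 1 to compound 2 (0.29 log units; that floor lies within the scatter), puts an aryl amine where the piperidin-1-yl stood, and its floor lies within the scatter, so the measured data give little to lean on.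

Compound 3 `CCOc1ccc(Nc2nc(SCc3ccc(C(F)(F)F)cc3)nc3ccccc23)cc1` is the next case. It differs from compound 1 by (4-ethoxyphenyl)amino in place of piperidin-1-yl on an aromatic carbon. This resembles the change from compound 1 to compound 2, as both bring an arylamino group to the same aromatic carbon, though compound 3 carries an ethoxy group instead of a chlorine. Within the data shown here, the only bearing step is therefore an at least 1.9-fold lower number from compound 1 to compound 2 (0.29 log units; that floor lies within the scatter), and a step of roughly that size toward a lower number is expected, while a limit again remains possible.

Compound 3 is estimated at 25000 nM in this assay, with a range from 8000 nM to 80000 nM. That estimate implies an expected at least 2.0-fold lower number from compound 1 to compound 3 (0.30 log units; that floor lies within the scatter).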

Compound 3, half-maximal inhibitory concentration: > 50000 nM
Compound 3 was reported as a limit (the forecaster's own chance of this, stated with the estimate: 35%); middle value at least 2.0-fold (0.30 log units) from the limit.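

Compound 3 is recorded in this assay at > 50000 nM, which is a limit of the assay and not a number. The step from compound 1 to compound 3 cannot be read, and the record shows only where both compounds sit: the limit of > 50000 nM in this assay, at which 2 of the 3 values shown sit.

Within the data shown here, the one readable step, an at least 1.9-fold higher number from compound 2 to compound 3 (0.29 log units; that floor lies within the scatter), puts 4-ethoxyphenyl in place of 3-chlorophenyl on the nitrogen, and it adds a new point: an arylamino group at this carbon does not by itself give a measured value, as compound 2 has one and compound 3 does not, although the printed floor gives no firm ground for separating these two compounds.

On these data alone, it remains open whether the ethoxy group, its place on the phenyl ring or neither decides the outcome, and a true value for compound 3 would be needed to judge this. A plain phenylamino group, or a phenylamino group carrying a methoxy group or a carboxylic acid, would test how far the read-out at this carbon depends on what the phenyl ring carries.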